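The source may hold more compounds than are shown below. What is called first, only, known or untested is meant among the compounds shown, and "the series" means these compounds.

In an ADME assay on MT4 cells (Homo sapiens) for cytotoxicity, read by MTT assay, with a stated time of 4 days (on this read-out lower numbers stand for higher toxicity in this test and higher numbers for lower toxicity in this test), compound 1 (`CC(=O)Nc1ccc(O)c(C(=O)/C=C/c2ccccc2F)c1`) gives 33800 nM, compound 2 (`CC(=O)Nc1ccc2oc(-c3ccccc3)cc(=O)c2c1`) gives 184000 nM and compound 3 (`CC(=O)Nc1ccc2oc(-c3ccccc3)c(O)c(=O)c2c1`) gives 64700 nM. Compound 3 therefore stands within the scatter of compound 1, while its number is clearly lower than that of compound 2. The next compound to be tested is compound 4 (`CC(=O)Nc1ccc2oc(-c3cccc(F)c3)c(O)c(=O)c2c1`), which differs from compound 3 by a single change: fluoro in place of hydrogen on an aromatic carbon. In words, fluoro takes the place of hydrogen on an aromatic carbon, turning phenyl into 3-fluorophenyl.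

Within the data shown here, only one measured step links two compounds that differ in one place: a 2.8-fold lower number from compound 2 to compound 3 (0.45 log units; beyond the scatter). That modest step comes from hydroxy replacing hydrogen, so it is a different change and offers only a rough guide to how far a single substitution can move the number in this series. Compound 1 also carries a fluoro group, but it differs from compound 3 in more than one place and cannot isolate the effect of this change. Among the measured compounds shown here, no measured pair tests fluoro in place of hydrogen directly, so no step beyond the scatter is expected in this assay. The expected step is a 1.1-fold lower number from compound 3 to compound 4 (0.05 log units; within the scatter). For compound 4, the estimated value is 58000 nM, with an expected range from 27000 nM to 120000 nM.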

Compound 4, half-maximal cytotoxic concentration: 26500 nM
The estimate for compound 4 lay 2.2-fold (0.34 log units) above the measured number; measured number outside the range, below it.
By their numbers in this assay, from the lowest: compounds 4, 1 and 3 (each within the scatter of the next, the first and the last beyond it); then compound 2.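

Turning phenyl into 3-fluorophenyl gives a 2.4-fold lower number from compound 3 to compound 4 (0.39 log units; beyond the scatter) in this assay and so shows that this place on the six-membered aromatic ring, unchanged among the earlier single-change pairs, can move the number beyond the scatter. A substitution of just one heavy atom here gives a modest step, as does the hydroxy change in a 2.8-fold lower number from compound 2 to compound 3 (0.45 log units; beyond the scatter) and both steps run toward a lower number, which in this test stands for higher toxicity; neither of these two single changes goes against that direction, although two steps make a thin basis for any wider pattern. Nothing available explains why the fluoro change has this effect.

On these data alone, it remains open whether the shift is specific to fluoro or would also follow from another group at the same place, such as chloro, methoxy, an amine or a carboxylic acid, and whether fluoro elsewhere on the ring would move the number in the same direction or by a similar amount. It is equally open whether the fluoro step depends on the hydroxy group that compound 3 and compound 4 share, since the compounds shown give this step only with that hydroxy group present.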